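Benzyl ring substitution in the naphthyl trimethoxyphenyl methane series

The compounds below may be only part of what the source reports. "The series", "measured", "known", "first", "only" and "open" are said of these compounds alone.

Compound 1 `COc1ccc(C(OCc2ccccc2)c2cccc3ccccc23)c(OC)c1OC` carries a benzyloxy group on the saturated chain carbon bound to two aromatic carbons. In a functional assay on MCF7 cells (Homo sapiens) for inhibition, read by sulforhodamine B assay, with a stated time of 48 h (on this read-out lower numbers stand for stronger inhibition and higher numbers for weaker inhibition), compound 1 gives 14100 nM. Compound 2 `COc1ccc(C(c2ccccc2O)c2cccc3ccccc23)c(OC)c1OC` gives 16600 nM in this assay, and compound 3 `COc1ccc(C(c2ccc(O)cc2)c2cccc3ccccc23)c(OC)c1OC` gives 17500 nM. The three numbers lie together: the step of a 1.2-fold higher number from compound 1 to compound 2 (0.07 log units; within the scatter), the step of a 1.2-fold higher number from compound 1 to compound 3 (0.09 log units; within the scatter) and the step of a 1.1-fold higher number from compound 2 to compound 3 (0.02 log units; within the scatter) all fall within the scatter, so compound 1 is not distinguishable from the other two on this read-out.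

Compound 4 `COC(=O)c1ccc(COC(c2ccc(OC)c(OC)c2OC)c2cccc3ccccc23)cc1` keeps the benzyloxy group of compound 1 and differs from it by methoxycarbonyl in place of hydrogen on an aromatic carbon. Among the compounds with values here, none of the measured steps bears on this change directly: each of them exchanges the benzyloxy group for a hydroxyphenyl group rather than adding a substituent to the benzyl ring. What the measured steps do show is that swapping the whole group at that chain carbon moves the number by less than the scatter in this assay. A single substituent on the benzyl ring is therefore expected to leave the number near that of compound 1, with no step beyond the scatter in either direction, as the expected step of a 1.0-fold lower number from compound 1 to compound 4 (0.00 log units; within the scatter) reflects. Compound 4 is expected to give 14000 nM in this assay, within a range from 6000 nM to 35000 nM.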

Compound 4, half-maximal inhibitory concentration: > 20000 nM
Compound 4 ended at the assay's limit; the forecaster's own chance of this, stated with the estimate: 5%; middle value at least 1.4-fold (0.15 log units) from the limit.
By their numbers in this assay, from the lowest: compounds 1, 2 and 3 (each within the scatter of the next). At a limit, above all of these: compound 4.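

In this assay compound 4 stands at a limit of the assay and not at a number: the limit of > 20000 nM in this assay, at which 1 of the 4 values shown sits.

With 4-(methoxycarbonyl)benzyl in place of benzyl, the series has its first member without a value inside the measured range, whereas the exchanges among compounds 1, 2 and 3 all stayed within the scatter of one another. On these data alone, the step reads an at least 1.4-fold higher number from compound 1 to compound 4 (0.15 log units; that floor lies within the scatter), so this floor alone does not separate the two compounds, and the true size of the step remains unknown: it could lie within the scatter or well beyond it.

The compounds shown leave open whether a carboxylic acid, an amine or a plain methyl at the same place on the aromatic ring would also reach the limit, or whether a number would return. They also leave open how methoxycarbonyl would read at another carbon of that ring, and a version of compound 4 that gives a number in a range reaching higher would be needed to size this change.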